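The compounds below may be only part of what the source reports. "The series", "measured", "known", "first", "only" and "open" are said of these compounds alone.

Working notes on the oxime-ether series in a functional assay on A549 cells (Homo sapiens) for cytotoxicity, read by MTT assay, with a stated time of 2 days; a lower number here means a stronger inhibitor, a higher number a weaker inhibitor.

Of the compounds shown here, three have numbers so far. Compound 1 `Fc1ccc2c(c1)/C(=N\OCc1ccccc1)C(c1c[nH]c3ccc(F)cc13)=N2` gives 10500 nM in this assay. Compound 2 `Cc1ccc(CO/N=C2/C(c3c[nH]c4ccccc34)=Nc3ccccc32)cc1` gives 22400 nM in this assay. Compound 3 `Cc1ccc(CO/N=C2/C(c3c[nH]c4ccc(Br)cc34)=Nc3ccc(Br)cc32)cc1` gives 13300 nM in this assay. Compound 3 thus stands second highest of the three numbers; its nearest neighbour is compound 1, and its furthest is compound 2, and both of those gaps lie within the usual scatter, so no order among the three can be read from these numbers.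

Compound 4 `Clc1cccc(CO/N=C2/C(c3c[nH]c4ccc(Br)cc34)=Nc3ccc(Br)cc32)c1` has not yet been measured. It differs from compound 3 in one place: 3-chlorophenyl in place of 4-methylphenyl on a saturated chain carbon bound to an oxygen on an unsaturated carbon. No step between two measured compounds matches this change, so there is no measured precedent in the series to lean on; the three numbers in hand all sit close together, which gives no reason to expect a large move in either direction.

On that basis the step from compound 3 to compound 4 is expected to be small, a 1.1-fold lower number from compound 3 to compound 4 (0.04 log units; within the scatter), none beyond the scatter. Compound 4 is estimated at 12000 nM in this assay, with a range from 5000 nM to 30000 nM.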

Compound 4, half-maximal inhibitory concentration: 12900 nM
The estimate for compound 4 lay 1.1-fold (0.03 log units) below the measured number; the measured number falls inside the stated range.
By their numbers in this assay, from the lowest: compounds 1, 4, 3 and 2 (each within the scatter of the next, the first and the last beyond it).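

In this assay, within the data shown here, the replacement of 4-methylphenyl by 3-chlorophenyl on a saturated chain carbon bound to an oxygen on an unsaturated carbon gives a 1.0-fold lower number from compound 3 to compound 4 (0.01 log units; within the scatter) and stays within the scatter, the first single-place comparison and so the first direct reading at this position. The two groups match in the counts computed for them, with 7 heavy atoms each, one six-membered aromatic ring of carbon only and no hydrogen-bond donors or acceptors, so this step tests an exchange of substituent and of its place on that ring while those counts stay the same, and it applies only to this pair on the core of compound 3. Nothing in hand explains why the number stays within the scatter across this change.

The compounds shown leave open whether the same position stays within the scatter with a group that differs more from these two, such as an aminomethyl or carboxylic acid on the phenyl ring, or a longer chain in place of the benzyl. They also leave open how 3-chlorophenyl compares with 4-chlorophenyl, which would separate the identity of the substituent from its place on the ring.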